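This account rests on a few compounds, and the source may have more. Where it says the series, first, only, none or still open, it means among the compounds named here.

The measured compounds are:
compound 1, `CC(C)C(=O)N1CC2CC(C1)N2`, with 20000 nM
compound 2, `O=C(C1CCCC1)N1CC2CC(C1)N2`, with 29000 nM

Both numbers come from an assay on SH-EP1 cells for agonist activity at Neuronal acetylcholine receptor; alpha4/beta2 (Homo sapiens), read by FLIPR and calcium flux; a higher number here means that more compound is needed for the effect, a lower number that less compound is needed. In this assay compound 1 gives 20000 nM, and compound 2 gives 29000 nM. These two values lie within the usual scatter of each other, so compound 1 cannot be said to need less or more compound than compound 2; it simply stands alongside it. The two share a core and differ only in the alkyl group on the carbonyl carbon whose other neighbours are an amide-type nitrogen in a ring.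

Compound 3, `C[C@H]1C[C@H]1C(=O)N1CC2CC(C1)N2`, has not yet been measured. 2-methylcyclopropyl in place of isopropyl on a carbonyl carbon Both groups are small, saturated hydrocarbon pieces. Because the isopropyl of compound 1 at 20000 nM and the cyclopentyl of compound 2 at 29000 nM gave numbers within the scatter, another small alkyl at the same place is expected to behave similarly. For compound 3 the expected step is no change at the digits printed from compound 1 to compound 3 (within the scatter), which is none beyond the scatter. Compound 3 is therefore estimated to give 20000 nM in this assay, with a likely range from 8000 nM to 60000 nM.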

Compound 3, half-maximal effective concentration: 5800 nM
Estimate against measurement, compound 3: 3.4-fold (0.54 log units) above; measured number below the stated range.
By their numbers in this assay, from the lowest: compound 3; then compounds 1 and 2 (each within the scatter of the next).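

In this assay, for the compounds shown here, the group on the carbonyl carbon turns out to matter: 2-methylcyclopropyl in place of isopropyl gives a 3.4-fold lower number from compound 1 to compound 3 (0.54 log units; beyond the scatter), a modest step but one beyond the scatter, whereas the isopropyl and cyclopentyl groups of the earlier compounds could not be told apart. This position therefore responds to which small hydrocarbon group it carries, even though both the entering and the leaving group are made of carbon only, with no hydrogen-bond donors or acceptors and no net charge. Nothing measured here explains the step.

On these data alone, it remains open whether the three-membered ring or its methyl group accounts for the lower number, a question that plain cyclopropyl would help to answer, and whether the other arrangements of the two defined stereocentres of compound 3 would give the same result. Also open, as far as these compounds go, is how this position would respond to a group that is not pure hydrocarbon, such as an amine or a carboxylic acid.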